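Replacing a Tertiary Alcohol by Ethylsulfanyl on the Core

The source may hold more compounds than are shown below. What is called first, only, known or untested is meant among the compounds shown, and "the series" means these compounds.

Compound 3 `CC(C)(O)C1CN(c2ccccc2)NC1=O` carries a 1-hydroxy-1-methylethyl group on a saturated ring carbon of the shared core. In an assay on isolated protein for inhibition of Polyunsaturated fatty acid 5-lipoxygenase (Rattus norvegicus) (a lower number here means a stronger inhibitor, a higher number a weaker inhibitor), compound 3 gives only > 1000 nM, which is a limit of the assay and not a number, as the limit of > 1000 nM in this assay, at which 1 of the 3 values shown sits, records. Its two ether-bearing relatives were measured with numbers: compound 1 `COCCOCC1CN(c2ccccc2)NC1=O` gives 520 nM and compound 2 `CCOCCC1CN(c2ccccc2)NC1=O` gives 150 nM. The step of an at least 6.6-fold higher number from compound 2 to compound 3 (0.82 log units; beyond the scatter) lies beyond the scatter, whereas the step of an at least 1.9-fold higher number from compound 1 to compound 3 (0.28 log units; that floor lies within the scatter) has a floor within the scatter; the step of a 3.5-fold lower number from compound 1 to compound 2 (0.54 log units; beyond the scatter) is modest.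

Compound 4 `CCSC1CN(c2ccccc2)NC1=O` has not yet been measured. The change from compound 3 is ethylsulfanyl in place of 1-hydroxy-1-methylethyl on a saturated ring carbon. The two measured steps into compound 3 point one way: the compound with the tertiary alcohol sits at the limit, while the two compounds with an oxygen-containing chain sit at measured numbers. Ethylsulfanyl resembles those chains more than it resembles the alcohol, so compound 4 is expected to come down from the limit to a measured number, a step of an at least 2.5-fold lower number from compound 3 to compound 4 (0.39 log units; beyond the scatter) toward a lower value. The estimate for compound 4 is 400 nM, between 100 nM and 2000 nM.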

Compound 4, half-maximal inhibitory concentration: 60 nM
Compound 4: middle estimate off by 6.7-fold (0.82 log units), on the high side, outside the stated range (below it).
By their numbers in this assay, from the lowest: compound 4; then compound 2; then compound 1. At a limit, above all of these: compound 3.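

At this position on the saturated ring carbon, ethylsulfanyl gives the lowest number of the series in this assay, with a 2.5-fold lower number from compound 2 to compound 4 (0.40 log units; beyond the scatter) and an 8.7-fold lower number from compound 1 to compound 4 (0.94 log units; beyond the scatter), so an ether oxygen in the chain is not needed for a low number among these compounds. Against the tertiary alcohol the change is larger, with an at least 16-fold lower number from compound 3 to compound 4 (1.22 log units; beyond the scatter), and it also removes the hydrogen-bond donor of 1-hydroxy-1-methylethyl. Compound 3 stays a limit of the assay and not a number, so the size of that step is only a floor: the limit of > 1000 nM in this assay, at which 1 of the 4 values shown sits.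

The compounds shown leave open whether the sulfur matters in itself, which an ethoxy group or a propyl chain on the same ring carbon would test against ethylsulfanyl. They also leave open whether the hydroxyl or the branching of 1-hydroxy-1-methylethyl goes with the limit of compound 3, a question that an isopropyl group or a 2-hydroxyethyl chain at this place would address.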